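Benzyl for methyl on a ring amine: expected cytotoxicity

The source may hold more compounds than are shown below. What is called first, only, known or untested is meant among the compounds shown, and "the series" means these compounds.

Measured compounds: compound 1 `N=C1S/C(=C\c2ccc(OCc3ccccc3)cc2)C(=O)N1c1cccc([N+](=O)[O-])c1` 52.9%; compound 2 `Cc1c(Cl)cccc1N1C(=N)S/C(=C\c2ccc(OCc3ccccc3)cc2)C1=O` 59.7%; compound 3 `CN1CCc2c(sc(NC(=O)c3ccc(Cl)cc3)c2C(N)=O)C1` 38.5%.

In an ADME assay on RAW264.7 cells (Mus musculus) for cytotoxicity, read by MTT assay, with a stated time of 48 h, tested at 50 uM (on this read-out lower numbers stand for less inhibition and higher numbers for more inhibition at the one concentration tested (going by the name of the read-out)), compound 3 stands lowest of the three, with compound 1 nearest and compound 2 furthest, both beyond the scatter. Compound 4 `NC(=O)c1c(NC(=O)c2ccc(Cl)cc2)sc2c1CCN(Cc1ccccc1)C2` differs from compound 3 in one place: phenyl in place of hydrogen on a saturated chain carbon bound to an amine nitrogen in a ring. Among the measured compounds shown here, the only measured step, a number 6.8 percentage points higher from compound 1 to compound 2 (within the scatter), lies on a different core and swaps one aromatic ring for another, so it does not bear on this change. For the measured compounds named here, no measured step matches phenyl entering at this position, so for compound 4 no step beyond the scatter is expected, with a number 3.5 percentage points higher from compound 3 to compound 4 (within the scatter) as the expected shift. Compound 4 is therefore estimated at 42%, ranging from 28% to 58%.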

Compound 4, a percentage reported as inhibition, at one concentration (the size of the read-out at that concentration, not a potency): 11.1%
Compound 4: the middle estimate sits 30.9 percentage points above what was measured, outside the stated range (below it).
By their numbers in this assay, from the lowest: compound 4; then compound 3; then compounds 1 and 2 (each within the scatter of the next).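

Methyl to benzyl, with phenyl in place of hydrogen on a saturated chain carbon bound to an amine nitrogen in a ring, is not a silent change in this assay: it gives a number 27.4 percentage points lower from compound 3 to compound 4 (beyond the scatter). This single pair shows that this place on the shared core can affect the read-out, and that adding phenyl here lowers it. Nothing measured here explains the drop. Going by these compounds, whether a longer chain or a cyclohexyl ring at this place would lower the number as well stays open.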